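From Amide to Urea on a Shared Core

A few compounds are considered here, and "the series" means these few. Any claim that something is new, unique, unknown or untested is made for them only; others in the source may bear on it.

compound 1 `CN(C(=O)c1ccc(Cl)cc1)c1ccc2[nH]c(-c3n[nH]c4ccccc34)cc2n1`: 2220 nM
compound 2 `COc1ccc(OC)c(S(=O)(=O)N(C)c2ccc3[nH]c(-c4n[nH]c5ccccc45)cc3n2)c1`: 19400 nM
compound 3 `CN(c1ccc2[nH]c(-c3n[nH]c4ccccc34)cc2n1)S(=O)(=O)c1ccc(OC(F)(F)F)cc1`: 8000 nM

Three measured compounds share one core and differ only in the group attached to the methylated nitrogen. In a functional assay on A549 cells (Homo sapiens) for antiproliferative activity, read by MTT assay, with a stated time of 72 h (a lower number here means a stronger inhibitor, a higher number a weaker inhibitor), compound 1 gives 2220 nM, the lowest of the three numbers; compound 3 gives 8000 nM and compound 2 gives 19400 nM. Within the data shown here, the one measured step, a 2.4-fold lower number from compound 2 to compound 3 (0.38 log units; beyond the scatter), concerns a group on a sulfonyl sulfur and says nothing about a carbonyl. Compound 4 `CN(C(=O)Nc1ccccc1)c1ccc2[nH]c(-c3n[nH]c4ccccc34)cc2n1` differs from compound 1 by anilino in place of 4-chlorophenyl on a carbonyl carbon. Among the measured compounds shown here, no measured step bears on this change, so a step of modest size at most is expected, with no clear direction: a 1.6-fold higher number from compound 1 to compound 4 (0.20 log units; within the scatter). Compound 4 is estimated at 3500 nM, within a range from 1000 nM to 12000 nM.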

Compound 4, half-maximal inhibitory concentration: 1430 nM
Estimate against measurement, compound 4: 2.4-fold (0.39 log units) above, and the stated range covers the measured number.
By their numbers in this assay, from the lowest: compounds 4 and 1 (each within the scatter of the next); then compound 3; then compound 2.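

In this assay, anilino in place of 4-chlorophenyl on a carbonyl carbon gives a 1.6-fold lower number from compound 1 to compound 4 (0.19 log units; within the scatter), so the two compounds cannot be told apart. At this position, then, the swap from an amide to a urea, which brings in a hydrogen-bond donor, leaves the number within the scatter. Nothing measured here explains this result.

Still open, as far as these compounds go, is whether a morpholine or a benzylamino group on the same carbonyl carbon would give a similar number. Also open, from the compounds shown here alone, is what a chlorine on the anilino ring would do.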